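A few compounds are considered here, and "the series" means these few. Any claim that something is new, unique, unknown or untested is made for them only; others in the source may bear on it.

Measured in a functional assay on G-361 cells (Homo sapiens) for inhibition, with a stated time of 72 h; a higher number here means a weaker inhibitor, a lower number a stronger inhibitor:
- Compound 1 `NC1CCC(Nc2nc(NCc3ccc(Br)cc3)c3ncn(C4CCCC4)c3n2)CC1`: 1480 nM
- Compound 2 `NC1CCC(Nc2nc(NCc3ccc(-c4cccc(F)c4)cc3)c3ncn(C4CCCC4)c3n2)CC1`: 815 nM
- Compound 3 `NC1CCC(Nc2nc(NCc3ccc(-c4ccco4)cc3)c3ncn(C4CCCC4)c3n2)CC1`: 164 nM

Compound 3 stands lowest of the three in this assay. Both steps that lead to it lie beyond the scatter: a 9.0-fold lower number from compound 1 to compound 3 (0.96 log units; beyond the scatter) and a 5.0-fold lower number from compound 2 to compound 3 (0.70 log units; beyond the scatter). By contrast, the step of a 1.8-fold lower number from compound 1 to compound 2 (0.26 log units; within the scatter) lies within the scatter.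

Compound 4 `NC1CCC(Nc2nc(NCc3ccc(-c4ccsc4)cc3)c3ncn(C4CCCC4)c3n2)CC1` keeps the shared core and has thiophen-3-yl in place of furan-2-yl on an aromatic carbon, para to a large group: thiophen-3-yl in place of furan-2-yl on an aromatic carbon. For the measured compounds named here, no measured step exchanges one five-membered aromatic ring for another, so the effect of this change has not been measured directly. The closest evidence is a 5.0-fold lower number from compound 2 to compound 3 (0.70 log units; beyond the scatter), which shows that the group at this place can shift the number beyond the scatter. Since both groups here are five-membered aromatic rings with one hetero atom, only a small change is expected, with a slightly higher number more likely than a lower one.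

The expected step is a 1.3-fold higher number from compound 3 to compound 4 (0.13 log units; within the scatter), which would not exceed the scatter. For compound 4 the estimated value is 220 nM, with an expected range of 90 nM to 550 nM.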

Compound 4, half-maximal inhibitory concentration: 570 nM
Beside the measured number, compound 4's estimate is 2.6-fold (0.41 log units) below it; measured number above the stated range.
By their numbers in this assay, from the lowest: compound 3; then compounds 4, 2 and 1 (each within the scatter of the next, the first and the last beyond it).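

In this assay, exchanging one five-membered aromatic ring for another at this place is not a neutral change: the step is a 3.5-fold higher number from compound 3 to compound 4 (0.54 log units; beyond the scatter) and lies beyond the scatter, although both groups have the same heavy-atom count. The low number of compound 3 is therefore tied to furan-2-yl itself and not to any five-membered aromatic ring with one hetero atom. Thiophen-3-yl still shows a 2.6-fold lower number from compound 1 to compound 4 (0.41 log units; beyond the scatter) against bromo, but it stands level with 3-fluorophenyl, with a 1.4-fold lower number from compound 2 to compound 4 (0.16 log units; within the scatter) inside the scatter.

This change alters the hetero atom and the point of attachment together, so thiophen-2-yl and furan-3-yl would be needed to separate the two, and a carboxylic acid or an aminomethyl group at this place remains an open case. No supporting measurement is available to explain the gap between compound 3 and compound 4.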